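Ester-Bearing Side Chains on a Shared Core

A few compounds are considered here, and "the series" means these few. Any claim that something is new, unique, unknown or untested is made for them only; others in the source may bear on it.

Three compounds with a common core have been examined in a functional assay on HEK293 cells for agonist activity at Toll-like receptor 8 (Homo sapiens), read by reporter gene assay; a lower number here means that less compound is needed, a higher number that more compound is needed for the effect. Compound 1 `CCCCCNc1oc2c(C)ncc(CO)c2c1Nc1ccccc1` gives 2250 nM in this assay. Compound 2 `CCOC(=O)CNc1oc2c(C)ncc(CO)c2c1Nc1ccccn1` is reported as "not active" (no number reported) in this assay, with no single number; compound 3 `Cc1ncc(CO)c2c(Nc3ccccn3)c(NC(C)(C)CC(C)(C)C)oc12` likewise stands as "not active" (no number reported) in this assay. Compound 2 therefore has no number to place it against compound 1, and compound 3 shares that position. Compound 4 `Cc1ncc(CO)c2c(Nc3ccccn3)c(NCCC(=O)OC(C)(C)C)oc12` has not been measured. It differs from compound 2 in one place: (tert-butoxycarbonyl)methyl in place of ethoxycarbonyl on a saturated chain carbon bound to a nitrogen on an aromatic ring. For the measured compounds named here, no step of this kind has been measured here. Since compound 2 gives no number, compound 4 is expected to reach only a weak effect, estimated at 8000 nM in this assay, within 2000 nM to 30000 nM, with a fair chance that only a limit is reported.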

Compound 4, half-maximal effective concentration: 7640 nM
Beside the measured number, compound 4's estimate is 1.0-fold (0.02 log units) above it; low and high end bracket the measured number.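

For the compounds shown here, compound 2 has no number in this assay, so no step from it to compound 4 can be read. No evidence here accounts for the response of compound 4. The compounds shown leave open how the side chain alone affects the response.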